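A few compounds are considered here, and "the series" means these few. Any claim that something is new, unique, unknown or untested is made for them only; others in the source may bear on it.

Measured compounds and their values:
Compound 1 `Cc1cccc(C(=O)Nc2ccc3c(c2)CC(NS(=O)(=O)c2cccs2)C3)c1-c1ccc(F)cc1` gives 1.4 nM in an assay for inhibition of apolipoprotein B-100 (Homo sapiens), tested at 100 nM; a higher number here means a weaker inhibitor, a lower number a stronger inhibitor.
Compound 2 `Cc1cccc(C(=O)Nc2ccc3c(c2)CC(NS(=O)(=O)c2cccs2)C3)c1-c1ccc(Cl)cc1` gives 3 nM in this assay.
Compound 3 `COC(=O)NC1CCc2ccc(NC(=O)c3cccc(C)c3-c3ccc(C(F)(F)F)cc3)cc2CC1` gives 1.6 nM in this assay.

Among these three numbers, compound 3 stands second highest. Its nearest neighbour is compound 1, and the gap between them lies within the usual scatter of repeated measurements; the gap to compound 2, the furthest, also lies within that scatter. Among the measured compounds shown here, the only change seen between measured compounds is a 2.1-fold higher number from compound 1 to compound 2 (0.33 log units; beyond the scatter), a swap of one halogen for another on the outer ring of a different core, and it is modest.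

Compound 4 `COC(=O)NC1CCc2ccc(NC(=O)c3cc(C)cc(C)c3-c3ccc(C(F)(F)F)cc3)cc2CC1` differs from compound 3 by methyl in place of hydrogen on an aromatic carbon, on a six-membered aromatic ring of carbon only, meta to a methyl group and para to a 4-(trifluoromethyl)phenyl group. For the measured compounds named here, no measured step involves a methyl added in this way, so the halogen swap between compound 1 and compound 2 offers only a loose guide to the size of change a small substituent can bring. The expected step is a 1.3-fold higher number from compound 3 to compound 4 (0.10 log units; within the scatter), which is not expected to exceed the usual scatter. For compound 4 the estimated value in this assay is 2 nM, with a range from 0.8 nM to 5 nM.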

Compound 4, half-maximal inhibitory concentration: 2.4 nM
Compound 4: middle estimate off by 1.2-fold (0.08 log units), on the low side, within the range that was stated.
By their numbers in this assay, from the lowest: compounds 1, 3, 4 and 2 (each within the scatter of the next, the first and the last beyond it).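

On the aromatic carbon para to a 4-(trifluoromethyl)phenyl group, methyl in place of hydrogen gives a 1.5-fold higher number from compound 3 to compound 4 (0.18 log units; within the scatter) in this assay and so leaves the two compounds indistinguishable in this measurement. Unlike the earlier halogen swap on the outer ring, this is a change on the ring that carries the amide carbonyl, and it shows that one added carbon at this position can be accommodated without a change beyond the scatter. No measurement shown here offers an explanation for this result.

At this carbon the compounds shown carry only hydrogen or methyl, so the effect of an amine, a carboxylic acid or a longer chain such as ethyl remains open. Also open, from the compounds shown here alone, is whether the same methyl would give a similar result on the core of compound 1.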